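Cytotoxicity limits across a thiazole and isoxazole pair

The compounds below may be only part of what the source reports. "The series", "measured", "known", "first", "only" and "open" are said of these compounds alone.

Compound 1 `COc1ccc(-c2nc(CO[C@@H]3COc4nc([N+](=O)[O-])cn4C3)cs2)cc1F`: in an ADME assay on Vero cells (Chlorocebus sabaeus) for cytotoxicity, with a stated time of 72 h (a lower number here means a stronger inhibitor, a higher number a weaker inhibitor), compound 1 gives a limit, > 128000 nM.
Compound 2 `COc1ccc(-c2nc(CO[C@@H]3COc4nc([N+](=O)[O-])cn4C3)cs2)cn1`: in this assay compound 2 gives a limit, > 128000 nM.
Compound 3 `COc1ccc(-c2cc(CO[C@@H]3COc4nc([N+](=O)[O-])cn4C3)on2)cc1F`: in this assay compound 3 gives a limit, > 128000 nM.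

Compound 4 `COc1ccc(-c2cc(CO[C@@H]3COc4nc([N+](=O)[O-])cn4C3)on2)cn1` has not yet been measured. From compound 1 to compound 2 the change is 6-methoxypyridin-3-yl in place of 3-fluoro-4-methoxyphenyl on an aromatic carbon, and in this assay that gave a step that the two limits leave unreadable from compound 1 to compound 2. From compound 3 to compound 4 the change is 6-methoxypyridin-3-yl in place of 3-fluoro-4-methoxyphenyl on an aromatic carbon; the surroundings differ, since in compound 1 the carbon is next to the ring sulfur while in compound 3 it is two ring bonds from the ring oxygen, so this is the same kind of change, not the same. The difference between the two cores is not broken down here. Because (the limit of > 128000 nM in this assay, at which 3 of the 3 values shown sit), compound 4 is expected to show a step that the limit leaves unreadable from compound 3 to compound 4, likewise unreadable. Compound 4 is thus estimated at 200000 nM, most likely again only a limit, between 100000 nM and 500000 nM.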

Compound 4, half-maximal inhibitory concentration: > 128000 nM
Compound 4 was reported as a limit; the forecaster's own chance of this, stated with the estimate: 85%; the middle value lies beyond the limit too.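

Compound 3 and compound 4 both give only a limit in this assay, so no step can be read between them: the limit of > 128000 nM in this assay, at which 4 of the 4 values shown sit.
The compounds shown leave open whether 6-methoxypyridin-3-yl in place of 3-fluoro-4-methoxyphenyl changes cytotoxicity at all on either core.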